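Nitro on the phenoxy ring of compound 3

This account rests on a few compounds, and the source may have more. Where it says the series, first, only, none or still open, it means among the compounds named here.

For the measured compounds named here, compound 3 `CC(C)(Oc1ccccc1)C1OCC(C/C=C\CCC(=O)O)C(c2cccnc2)O1` gives 75.9 nM in a functional assay for inhibition, with Homo sapiens as the target (a lower number here means tighter binding, a higher number weaker binding), the lowest of the three numbers so far. Compound 1 `O=C(O)CC/C=C\CC1COC(c2ccc(Cl)cc2Cl)OC1c1cccnc1` gives 891 nM and compound 2 `O=C(O)CC/C=C\CC1COC(c2ccc3ccccc3c2)OC1c1cccnc1` gives 1780 nM in this assay; the steps of a 12-fold lower number from compound 1 to compound 3 (1.07 log units; beyond the scatter) and a 23-fold lower number from compound 2 to compound 3 (1.37 log units; beyond the scatter) are large, whereas a 2.0-fold higher number from compound 1 to compound 2 (0.30 log units; within the scatter) is not. Compound 4 `CC(C)(Oc1ccccc1[N+](=O)[O-])C1OCC(C/C=C\CCC(=O)O)C(c2cccnc2)O1` differs from compound 3 by nitro in place of hydrogen on an aromatic carbon. Going by the values given here, every measured step exchanges the whole group on the saturated ring carbon; none varies a substituent on an aromatic ring inside that group, so no measured step bears directly on this change. For compound 4 the expectation in this assay is therefore a step no larger than the scatter, a 1.1-fold higher number from compound 3 to compound 4 (0.02 log units; within the scatter), held with a wide range. Compound 4 is estimated at 80 nM, between 25 nM and 250 nM.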

Compound 4, dissociation constant: 11.2 nM
Compound 4: the middle estimate sits 7.1-fold (0.85 log units) above what was measured; measured number outside the range, below it.
By their numbers in this assay, from the lowest: compound 4; then compound 3; then compounds 1 and 2 (each within the scatter of the next).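

In this assay, for the compounds shown here, the 2-nitrophenoxy group gives a 6.8-fold lower number from compound 3 to compound 4 (0.83 log units; beyond the scatter) and so, unlike the earlier steps, which exchange the whole group on the saturated ring carbon, this step shows that a substituent on the aromatic ring inside that group, ortho to a large group, can move the number beyond the scatter. No measurement available here accounts for this shift.

As far as these compounds go, whether an amine, a methoxy group or a chlorine atom in the same place moves the number likewise stays open. So does the outcome of nitro elsewhere on this ring.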